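Hydrogen for tert-butoxycarbonyl on the ring amine, second instance

A few compounds are considered here, and "the series" means these few. Any claim that something is new, unique, unknown or untested is made for them only; others in the source may bear on it.

Compound 1 `C=CC[C@@]12CCN[C@@H]1n1c3nc4ccc(O)cc4cc3c(=O)c3cccc2c31` and compound 2 `C=CC[C@@]12CCN(C(=O)OC(C)(C)C)[C@@H]1n1c3nc4ccc(O)cc4cc3c(=O)c3cccc2c31` share one core; compound 2 carries a tert-butoxycarbonyl on the ring amine where compound 1 carries hydrogen. In a functional assay on NCI-H460 cells (Homo sapiens) for inhibition, read by trypan blue exclusion, with a stated time of 72 h (on this read-out lower numbers stand for stronger inhibition of growth and higher numbers for weaker inhibition of growth), compound 1 gives 50000 nM, while compound 2 gives 32700 nM. The change hydrogen in place of tert-butoxycarbonyl on an amine nitrogen in a ring thus produced a step of a 1.5-fold higher number from compound 2 to compound 1 (0.18 log units; within the scatter).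

Compound 3 `C=CC[C@@]12CCN(C(=O)OC(C)(C)C)[C@@H]1n1c3nc4ccc(O)c(CN(C)C)c4cc3c(=O)c3cccc2c31` differs from compound 2 by (dimethylamino)methyl in place of hydrogen on an aromatic carbon; in this assay compound 3 gives 17800 nM, a step of a 1.8-fold lower number from compound 2 to compound 3 (0.26 log units; within the scatter). Compound 4 `C=CC[C@@]12CCN[C@@H]1n1c3nc4ccc(O)c(CN(C)C)c4cc3c(=O)c3cccc2c31` has not been measured; it differs from compound 3 by hydrogen in place of tert-butoxycarbonyl on an amine nitrogen in a ring. This is the same change as that made from compound 2 to compound 1: the group that leaves, the hydrogen that enters and the place of the change are described in identical words for both pairs. The cores of the two pairs differ only by the (dimethylamino)methyl change already given between compound 2 and compound 3.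

All three measured numbers sit close together, and neither measured step reaches beyond the scatter. Going by the values given here, the step from compound 3 to compound 4 in this assay is expected to be a 1.5-fold higher number from compound 3 to compound 4 (0.18 log units; within the scatter), of about the same size as the earlier one, because the only precedent for this change is a 1.5-fold higher number from compound 2 to compound 1 (0.18 log units; within the scatter) on a core that differs by one small group. Compound 4 is therefore estimated at 27000 nM, with a range from 12000 nM to 60000 nM expected to cover repeat measurements.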

Compound 4, concentration for 50% growth inhibition: 26200 nM
Estimate against measurement, compound 4: 1.0-fold (0.01 log units) above; the measured number falls inside the stated range.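

In this assay, hydrogen in place of tert-butoxycarbonyl on the ring amine gives a 1.5-fold higher number from compound 3 to compound 4 (0.17 log units; within the scatter) on the core bearing (dimethylamino)methyl, and this step agrees with the one on the core without that group: the same change on two cores in this assay, a 1.5-fold higher number (0.18 log units; within the scatter) from compound 2 to compound 1 and a 1.5-fold higher number (0.17 log units; within the scatter) from compound 3 to compound 4, 1.0-fold (0.02 log units) apart, within the scatter of two such steps

The (dimethylamino)methyl change reads the same way on the core with hydrogen on the ring amine, a 1.9-fold lower number from compound 1 to compound 4 (0.28 log units; within the scatter), and it agrees with its earlier step on the core bearing tert-butoxycarbonyl: the same change on two cores in this assay, a 1.8-fold lower number (0.26 log units; within the scatter) from compound 2 to compound 3 and a 1.9-fold lower number (0.28 log units; within the scatter) from compound 1 to compound 4, 1.0-fold (0.02 log units) apart, within the scatter of two such steps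

Across these four compounds, each change therefore carries from one core to the other without a visible difference, but all four steps lie within the scatter, so this is agreement among small steps and does not show that either change has a real effect of its own, or that the two changes would stay independent on other cores or at larger step sizes.

The compounds shown hold only hydrogen or tert-butoxycarbonyl on the ring amine and only hydrogen or (dimethylamino)methyl on the aromatic carbon, which leaves open how an acetyl or methyl group on that nitrogen, or a morpholinomethyl or pyrrolidinylmethyl group on that carbon, would read. From the compounds shown here alone, the allyl group is also constant throughout, so it remains open whether a propyl group or a longer chain in its place would leave these steps as they are.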